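This account rests on a few compounds, and the source may have more. Where it says the series, first, only, none or still open, it means among the compounds named here.

Measured compounds:
compound 1 `C/[N+]([O-])=C1\C(=O)Nc2ccc([N+](=O)[O-])cc21` — 1200 nM
compound 2 `O=C1Nc2ccccc2/C1=[N+](\[O-])c1ccccc1` — 1300 nM

In a functional assay, read by spectrophotometry, with a stated time of 10 min (on this read-out lower numbers stand for an effect already at smaller amounts and higher numbers for an effect only at larger amounts of compound), compound 1 gives 1200 nM and compound 2 gives 1300 nM. Compound 1 has the lowest of the two numbers, but compound 2 lies within the scatter of it, so the two are not distinguishable in this assay. Among the compounds with values here, no single-change step between measured compounds is available.

The next compound, compound 3 `O=C1Nc2ccc([N+](=O)[O-])cc2/C1=[N+](\[O-])Cc1ccccc1`, is to be measured in this assay. Relative to compound 1 the change is phenyl in place of hydrogen on a saturated chain carbon bound to a double-bonded nitrogen. Within the data shown here, nothing measured so far tells how this assay responds to such a change, so a step from compound 1 to compound 3 is expected to stay within the usual scatter rather than move clearly in either direction. The expected step is a 1.2-fold lower number from compound 1 to compound 3 (0.08 log units; within the scatter). For compound 3 the estimate in this assay is 1000 nM, with a range from 350 nM to 3000 nM.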

Compound 3, half-maximal effective concentration: 1000 nM
Compound 3: middle estimate and measured number agree at the digits printed, and the stated range covers the measured number.
By their numbers in this assay, from the lowest: compounds 3, 1 and 2 (each within the scatter of the next).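

At the saturated chain carbon bound to a double-bonded nitrogen, phenyl in place of hydrogen, which reads as methyl to benzyl, gives in this assay a 1.2-fold lower number from compound 1 to compound 3 (0.08 log units; within the scatter). Within the data shown here, this is the first single-change step, and it shows that this position can carry a six-membered aromatic ring of carbon without the number leaving the scatter of compound 1. No measurement available here bears on why the read-out stays level across this change.

On these data alone, whether an amine, a carboxylic acid or a longer chain ending in phenyl at the same place would move the number beyond the scatter remains open. The contribution of the nitro group on the shared core also remains open, as the compounds shown offer no pair that differs there alone.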